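The source may hold more compounds than are shown below. What is called first, only, known or untested is meant among the compounds shown, and "the series" means these compounds.

Working notes on the series. Compound 3 `CCCS(=O)(=O)Nc1ccc(F)c(C(=O)c2n[nH]c3ncc(-c4ccc(OC)cc4Cl)cc23)c1F` gives 5.3% in an assay for binding affinity to dual specificity mitogen-activated protein kinase kinase 4 (Homo sapiens), read by KINOMEscan, tested at 100 nM; on this read-out lower numbers stand for a stronger effect and higher numbers for a weaker effect at the one concentration tested. Compound 1 `CCCS(=O)(=O)Nc1ccc(F)c(C(=O)c2n[nH]c3ncc(-c4ccccc4)cc23)c1F` gives 2.4% and compound 2 `CCCS(=O)(=O)Nc1ccc(F)c(C(=O)c2n[nH]c3ncc(-c4ccc(O)cc4)cc23)c1F` gives 0.75%; the steps of a number 2.9 percentage points higher from compound 1 to compound 3 (within the scatter) and a number 4.6 percentage points higher from compound 2 to compound 3 (within the scatter) show that all three numbers sit within the scatter of one another. Compound 4 `CCCS(=O)(=O)Nc1ccc(F)c(C(=O)c2n[nH]c3ncc(-c4ccc(-c5nnn[nH]5)cc4)cc23)c1F` differs from compound 3 as follows: 4-(1H-tetrazol-5-yl)phenyl in place of 2-chloro-4-methoxyphenyl on an aromatic carbon. Within the data shown here, the steps that bear on this are a number 2.9 percentage points higher from compound 1 to compound 3 (within the scatter) and a number 1.7 percentage points lower from compound 1 to compound 2 (within the scatter), both changes at the same aromatic carbon and both within the scatter; no measured step covers a tetrazolyl group. Compound 4 is therefore expected to show no step beyond the scatter, a number 1.3 percentage points lower from compound 3 to compound 4 (within the scatter), and its estimated value is 4% with a range from 0.5% to 25%.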

Compound 4, a percentage reported as activity, at one concentration (the size of the read-out at that concentration, not a potency): 0.15%
For compound 4 the middle estimate is 3.9 percentage points above the measured one; measured number outside the range, below it.
By their numbers in this assay, from the lowest: compounds 4, 2, 1 and 3 (each within the scatter of the next).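

At this aromatic carbon, a tetrazolyl ring carried on the phenyl group, the first five-membered aromatic ring with hetero atoms here, leaves the number in this assay within the scatter of all three earlier compounds (a number 5.2 percentage points lower from compound 3 to compound 4 (within the scatter)) (a number 0.6 percentage points lower from compound 2 to compound 4 (within the scatter)) (a number 2.3 percentage points lower from compound 1 to compound 4 (within the scatter)). The four compounds therefore give no order at this position. Nothing measured here bears on why the number holds. As far as these compounds go, whether a carboxylic acid or an amine in place of the 1H-tetrazol-5-yl group would move the number beyond the scatter stays open. Potency also stays open, with only one concentration shown.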